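The compounds below may be only part of what the source reports. "The series", "measured", "known", "first", "only" and "open" are said of these compounds alone.

Values in a functional assay on HeLa cells (Homo sapiens) for antiproliferative activity, read by cell counting, with a stated time of 72 h (a lower number here means a stronger inhibitor, a higher number a weaker inhibitor), measured so far:
Compound 1 `C#C[C@@]1(O)[C@@H](CO)O[C@@H](n2cc(C(F)(F)F)c3c(N)ncnc32)[C@@H]1O` gives 750 nM
Compound 2 `C#Cc1cn([C@@H]2O[C@H](CO)[C@](O)(C#C)[C@H]2O)c2ncnc(N)c12` gives 114000 nM
Compound 3 `C#C[C@@]1(O)[C@@H](CO)O[C@@H](n2cc(Cl)c3c(Cl)ccnc32)[C@@H]1O` gives 6300 nM

Compound 3 holds the middle of the three numbers, higher than compound 1 and lower than compound 2. Compound 4 `C#C[C@@]1(O)[C@@H](CO)O[C@@H](n2cc(I)c3c(Cl)ccnc32)[C@@H]1O` differs from compound 3 by iodo in place of chloro on an aromatic carbon and is thus iodo in place of chloro on an aromatic carbon. No such exchange has been measured. Among the compounds with values here, the only measured step, a 150-fold higher number from compound 1 to compound 2 (2.18 log units; beyond the scatter) for ethynyl in place of trifluoromethyl on an aromatic carbon, is large, but it belongs to the core of compound 1 and involves other groups. In this assay no firm direction is therefore expected, and the likeliest outcome is a step within or near the scatter, with a wide margin. The expected change is a 1.1-fold higher number from compound 3 to compound 4 (0.05 log units; within the scatter) in this estimate. For compound 4 the estimated value is 7000 nM with an expected range from 1800 nM to 28000 nM in this series.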

Compound 4, half-maximal inhibitory concentration: 1100 nM
For compound 4 the middle estimate is 6.4-fold (0.80 log units) above the measured one, outside the stated range (below it).
By their numbers in this assay, from the lowest: compounds 1 and 4 (each within the scatter of the next); then compound 3; then compound 2.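

In this assay, exchanging one halogen for another on this aromatic carbon moves the result beyond the scatter, with a 5.7-fold lower number from compound 3 to compound 4 (0.76 log units; beyond the scatter). Within the data shown here, the earlier step at a substituted aromatic carbon involved only trifluoromethyl and ethynyl on the core of compound 1, so this is the first sign that the choice of halogen matters on the core of compound 3. No measured evidence accounts for the stronger inhibition with iodo.

Where bromo or an amine would fall at this position remains open. Also open, going by these compounds, is whether iodo would give a comparable step on the core of compound 1.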